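Swapping the anilino arm of a purine benzamide

A few compounds are considered here, and "the series" means these few. Any claim that something is new, unique, unknown or untested is made for them only; others in the source may bear on it.

Measured so far:
compound 1 `Nc1ccccc1NC(=O)/C=C/c1ccc(Cn2cnc3c(Nc4cccc(Cl)c4)nc(Cl)nc32)cc1` — 7.11%
compound 2 `Nc1ccccc1NC(=O)c1ccc(Cn2cnc3c(Nc4ccc(-c5ccccn5)cc4)nc(Cl)nc32)cc1` — 18.1%

In a functional assay on NCI-H460 cells (Homo sapiens) for antiproliferative activity, read by CCK-8 assay, with a stated time of 72 h, tested at 2 uM (on this read-out higher numbers stand for a stronger effect at the one concentration tested and lower numbers for a weaker effect), compound 2 gives the higher of the two numbers, and compound 1 lies lower by more than the usual scatter. Compound 3 `Nc1ccccc1NC(=O)c1ccc(Cn2cnc3c(Nc4cccc(Cl)c4)nc(Cl)nc32)cc1` has not been measured. Its change from compound 2 is 3-chlorophenyl in place of 4-(pyridin-2-yl)phenyl on a nitrogen on an aromatic ring. Compound 3 thus carries the same 3-chlorophenyl as compound 1 while keeping the amide of compound 2. In this assay a modest downward step from compound 2 is expected, at about the edge of the scatter. The expected step comes to a number 8.1 percentage points lower from compound 2 to compound 3 (within the scatter). Compound 3 is expected to give 10%, within a range from 2% to 22%.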

Compound 3, a percentage reported as inhibition, at one concentration (the size of the read-out at that concentration, not a potency): 10.3%
Beside the measured number, compound 3's estimate is 0.3 percentage points below it, and the stated range covers the measured number.
By their numbers in this assay, from the lowest: compounds 1, 3 and 2 (each within the scatter of the next, the first and the last beyond it).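

In this assay putting 3-chlorophenyl in place of 4-(pyridin-2-yl)phenyl on a nitrogen on an aromatic ring gives a number 7.8 percentage points lower from compound 2 to compound 3 (within the scatter) and so, on its own, this change does not clearly alter the read-out. Putting (2-aminophenyl)carbamoyl in place of 2-((2-aminophenyl)carbamoyl)ethenyl on an aromatic carbon gives a number 3.2 percentage points higher from compound 1 to compound 3 (within the scatter) in the read-out. Thus the gap beyond the scatter between compound 1 and compound 2 splits into two steps that each stay within it. No measurement on hand offers an explanation for either step.

Going by these compounds, whether a plain phenyl or a 4-methoxyphenyl on that nitrogen would differ from compound 3 by more than the scatter remains open.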